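This account rests on a few compounds, and the source may have more. Where it says the series, first, only, none or still open, it means among the compounds named here.

Among the measured compounds shown here, compound 1 `Cn1c(-c2cccc(Cl)c2)nc2c(NC3CCCC3)ncnc21` is one of three compounds measured so far; the others are compound 2 `CCn1c(-c2ccccc2)nc2c(NC3CCCCC3)ncnc21` and compound 3 `CCn1c(-c2ccccc2)nc2c(NC3CCCC3)ncnc21`. In an assay on CHO cells for displacement of a labelled ligand from adenosine receptor A3 (Homo sapiens), read by scintillation counting, with a stated time of 3 h (a higher number here means a weaker inhibitor, a lower number a stronger inhibitor), compound 1 gives 514 nM, compound 2 gives 707 nM and compound 3 gives 354 nM. All three numbers lie within the scatter of one another, so compound 1 cannot be placed above or below its neighbours on these data. For the measured compounds named here, the only step between two compounds that differ in one place is a 2.0-fold lower number from compound 2 to compound 3 (0.30 log units; within the scatter), and it concerns the group on a nitrogen on an aromatic ring, not the aromatic carbon changed here.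

Compound 4 `Cn1c(-c2cccnc2)nc2c(NC3CCCC3)ncnc21` has not yet been measured; it differs from compound 1 by pyridin-3-yl in place of 3-chlorophenyl on an aromatic carbon. Going by the values given here, no measured step touches this exchange, so the expectation rests on the structural change alone. The expected step is a 1.6-fold higher number from compound 1 to compound 4 (0.19 log units; within the scatter), with a slight lean toward a higher number and wide uncertainty. Compound 4 is therefore estimated at 800 nM, in a range from 250 nM to 2500 nM.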

Compound 4, inhibition constant: 11000 nM
Beside the measured number, compound 4's estimate is 14-fold (1.14 log units) below it; the whole stated range lies below it.
By their numbers in this assay, from the lowest: compounds 3, 1 and 2 (each within the scatter of the next); then compound 4.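

In this assay the group on this aromatic carbon, between two ring nitrogen atoms, clearly matters: pyridin-3-yl in place of 3-chlorophenyl gives a 21-fold higher number from compound 1 to compound 4 (1.33 log units; beyond the scatter), the first step shown here that lies beyond the scatter. The exchange alters two things at once, since the chlorine leaves and a ring nitrogen enters, and this single step cannot separate the two. No measurement available here explains the large rise in the number.

The compounds shown leave open whether the chlorine's departure or the ring nitrogen's arrival accounts for the step. They also leave open how other groups on this carbon would read, such as 3-methoxyphenyl, or pyridin-4-yl with its ring nitrogen placed elsewhere.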